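Carbamate and thiocarbamate variation in an insulinotropic receptor series

The compounds below may be only part of what the source reports. "The series", "measured", "known", "first", "only" and "open" are said of these compounds alone.

Compound 1 `CC(C)OC(=O)N1CCC(Oc2cccc3c2CCN3c2ccc(S(C)(=O)=O)cc2)CC1` gives 70% in a functional assay on CHO-K1 cells with Glucose-dependent insulinotropic receptor (Homo sapiens) as the target, read by a luciferase reporter, with a stated time of 5 h; on this read-out higher numbers stand for larger maximal responses and lower numbers for smaller maximal responses. Compound 2 `CC(C)(C)OC(=O)N1CCC(Oc2cccc3c2CCN3c2ccc(S(C)(=O)=O)cc2)CC1` differs by methyl in place of hydrogen on a saturated chain carbon bound to an oxygen next to a carbonyl group and two saturated chain carbons and in this assay compound 2 gives 92%; the step is a number 22 percentage points higher from compound 1 to compound 2 (beyond the scatter). Compound 3 `CSC(=O)N1CCC(Oc2ncnc3c2CCN3c2ccc(S(C)(=O)=O)cc2F)CC1` carries a different core; the difference between the two cores is not broken down here. In this assay compound 3 gives 135%, the highest of the three numbers. Compound 4 `CCSC(=O)N1CCC(Oc2ncnc3c2CCN3c2ccc(S(C)(=O)=O)cc2F)CC1` differs from compound 3 by methyl in place of hydrogen on a saturated chain carbon bound to a sulfur, the same kind of change as from compound 1 to compound 2, but the place differs: there the carbon is bound to an oxygen next to a carbonyl group and two saturated chain carbons, here to a sulfur. Among the measured compounds shown here, the step from compound 3 to compound 4 is expected to be a number 10 percentage points higher from compound 3 to compound 4 (within the scatter), resting on the single earlier step of a number 22 percentage points higher from compound 1 to compound 2 (beyond the scatter) and the different surroundings. Compound 4 is estimated at 145%, with a range from 115% to 175%.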

Compound 4, largest response reached (reported as percent of maximum), in percent of the reference or control that the assay uses: 128%
Compound 4: the middle estimate sits 17 percentage points above what was measured; the range from low to high includes it.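

In this assay, methyl in place of hydrogen on the saturated chain carbon bound to a sulfur gives a number 7 percentage points lower from compound 3 to compound 4 (within the scatter), so methyl to ethyl on the thiocarbamate of compound 3 leaves no change that can be told from the scatter. The added methyl does not carry over as one fixed increment from one core to the other: the same change on two cores in this assay, a number 22 percentage points higher (beyond the scatter) from compound 1 to compound 2 and a number 7 percentage points lower (within the scatter) from compound 3 to compound 4, 29 percentage points apart, beyond the scatter of two such steps. With a single pair on each core, and with the core and the carbon bearing the methyl both differing between the pairs, these data do not show which difference accounts for the gap.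

The compounds shown leave open how a propyl or isopropyl chain on the sulfur would read. Also open, from the compounds shown here alone, is how an oxygen carbamate would read on the core of compound 3, and a thiocarbamate on the core of compound 1.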